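The compounds below may be only part of what the source reports. "The series", "measured", "known", "first", "only" and "open" are said of these compounds alone.

Measured so far in a functional assay on the whole organism (strain Wister albino) for inhibition, with Rattus norvegicus as the target, read by paw edema, with stated times of 1 h and 4 h, at a dose of 50 mg/kg by the intraperitoneal route; on this read-out higher numbers stand for more inhibition at the one dose given (going by the name of the read-out) and lower numbers for less inhibition:
- compound 1 `CN1C[C@@H](c2ccccc2)[C@@]2(Cc3ccccc3C2=O)[C@@]12C(=O)Nc1ccccc12` gives 39.3%
- compound 2 `CN1C[C@@H](c2ccc(F)cc2)[C@@]2(Cc3ccccc3C2=O)[C@@]12C(=O)Nc1ccccc12` gives 21.8%
- compound 3 `Cc1ccc([C@@H]2CN(C)[C@]3(C(=O)N(C)c4ccccc43)[C@]23Cc2ccccc2C3=O)cc1` gives 13.9%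

Among these three numbers compound 1 stands highest, ahead of compound 2 and further ahead of compound 3, and both gaps lie beyond the usual scatter. Compound 4 `CN1C[C@@H](c2ccco2)[C@@]2(Cc3ccccc3C2=O)[C@@]12C(=O)Nc1ccccc12` has not yet been measured. It differs from compound 1 in one place: furan-2-yl in place of phenyl on a saturated ring carbon.

Among the measured compounds shown here, only one measured step changes a single feature: a number 17.5 percentage points lower from compound 1 to compound 2 (beyond the scatter), where a small substituent was added to the same aryl ring. Compound 3 differs from compound 1 in two places and so cannot be read as a single step; its value merely shows a lower number than compound 1. Neither case replaces the whole ring, so the bearing on compound 4 is indirect. The two altered aryl analogues both give a lower number than compound 1, which suggests that changes at this ring tend to go with a lower number in this assay, though with only two cases this rests on little. A modest drop in this assay is therefore expected, a number 12.3 percentage points lower from compound 1 to compound 4 (beyond the scatter), and compound 4 is estimated at 27%, within a range from 12% to 42%.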

Compound 4, a percentage reported as inhibition, in the whole organism at one dose (the size of the read-out at that dose, not a potency): 33.5%
Compound 4: middle estimate off by 6.5 percentage points, on the low side, and the stated range covers the measured number.
By their numbers in this assay, from the lowest: compounds 3 and 2 (each within the scatter of the next); then compounds 4 and 1 (each within the scatter of the next).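

In this assay the whole phenyl ring can be exchanged for furan-2-yl, a five-membered aromatic ring with one oxygen, and the result is a number 5.8 percentage points lower from compound 1 to compound 4 (within the scatter), so the two compounds cannot be told apart. Compound 2, the only earlier single change at this ring, had shown a clear drop, so compound 4 shows that a change on this saturated ring carbon need not cost activity, even when the entire ring is replaced. Replacing 4-fluorophenyl with furan-2-yl gives a number 11.7 percentage points higher from compound 2 to compound 4 (beyond the scatter), which shows that the choice of ring here can shift the number by a modest but real amount.

Going by these compounds, whether thiophene, pyridine, cyclohexyl or a ring bearing an amine or a carboxylic acid would fit this carbon as well remains open. Nothing available explains why these ring changes differ in this way.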